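This account rests on a few compounds, and the source may have more. Where it says the series, first, only, none or still open, it means among the compounds named here.

Measured so far:
Compound 1 `O=C(NC1CCCCC1)c1cnn2c(C(F)F)cc(C3CC3)nc12`: "not determined" (no result reported)
Compound 2 `CC1(C)CC(NC(=O)c2cnn3c(C(F)F)cc(C4CC4)nc23)c2ccccc2O1`: 2300 nM

In a functional assay on Daoy cells (Homo sapiens) for antiproliferative activity, read by trypan blue exclusion and crystal violet staining, with a stated time of 72 h (a higher number here means a weaker inhibitor, a lower number a stronger inhibitor), compound 2 gives 2300 nM. Going by the values given here, this is the only number available: compound 1 gives "not determined" (no result reported), so compound 2 can't yet be ranked against anything, and it serves only as a starting point.

The next compound to be tested is compound 3 `Cc1cc(C(F)F)n2ncc(C(=O)NC3CC(C)(C)Oc4ccccc43)c2n1`. It matches compound 2 except at one place: methyl in place of cyclopropyl on an aromatic carbon. The group that changes sits next to the ring nitrogen and meta to a difluoromethyl group.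

Among the compounds with values here, no pair of measured compounds shows what a change like this does in this assay, so any forecast is loose. Taking compound 2 at 2300 nM as the anchor, a small loss of strength is expected, and it may well stay within the usual scatter of repeated measurements. The expected size of this change is a 1.5-fold higher number from compound 2 to compound 3 (0.18 log units; within the scatter). For compound 3 the estimated value is 3500 nM, with an expected range from 1300 nM to 10000 nM.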

Compound 3, half-maximal inhibitory concentration: "not active" (no number reported)
For compound 3 the study gives words and no number; there is nothing to compare the estimate with.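

In this assay, going by these compounds alone, compound 3 is reported only in words, as "not active" (no number reported), so no step from compound 2 can be read. No available evidence bears on this result. How far replacing cyclopropyl with methyl shifts antiproliferative strength stays open, as does any numerical ranking of these compounds.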